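Fluoro for nitro on the phenoxy ring of compound 2

The source may hold more compounds than are shown below. What is called first, only, known or untested is meant among the compounds shown, and "the series" means these compounds.

Compound 2 `Cc1nc2ccccc2c(=O)n1/N=C/c1ccc(Oc2ccc([N+](=O)[O-])cc2)cc1` gives 4.01 in a physicochemical assay for lipophilicity, in phosphate buffer, measured as octanol-water partition (on this read-out lower numbers stand for lower lipophilicity and higher numbers for higher lipophilicity), the lowest of the three values shown. Among the compounds with values here, compound 1 `CCCc1nc2ccccc2c(=O)n1/N=C/c1ccc(Oc2ccc(Br)cc2)cc1` gives 5.88, and compound 3 `O=c1c2ccccc2nc(-c2ccccc2)n1/N=C/c1ccc(Oc2ccc([N+](=O)[O-])cc2)cc1` gives 6.12; the one measured step, a number 2.11 log units higher from compound 2 to compound 3 (beyond the scatter), concerns phenyl in place of methyl and does not bear on the change at hand. Compound 4 `Cc1nc2ccccc2c(=O)n1/N=C/c1ccc(Oc2ccc(F)cc2)cc1` differs from compound 2 in one place: fluoro in place of nitro on an aromatic carbon. Within the data shown here, no measured pair isolates this exchange, and compound 1 differs from compound 2 in two places at once, so the expectation rests on the change alone. A modest rise is expected, a number 0.39 log units higher from compound 2 to compound 4 (beyond the scatter), so the account estimates compound 4 at 4.4, within 3.9 to 4.9.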

Compound 4, partition coefficient: 4.21
Compound 4: the middle estimate sits 0.19 log units above what was measured, and the stated range covers the measured number.
By their numbers in this assay, from the lowest: compounds 2 and 4 (each within the scatter of the next); then compounds 1 and 3 (each within the scatter of the next).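

Going from 4-nitrophenoxy to 4-fluorophenoxy in this assay gives a number 0.20 log units higher from compound 2 to compound 4 (within the scatter), so on this read-out the two groups cannot be told apart at this position of the shared core. The earlier step, a number 2.11 log units higher from compound 2 to compound 3 (beyond the scatter), lay elsewhere on the core and beyond the scatter; this exchange on the phenoxy ring does not. Nothing available explains why nitro and fluoro read alike here.

On these data alone, it remains open whether the exchange would read the same with the phenyl of compound 3 in place of methyl. As far as these compounds go, what an amine or a carboxylic acid would give at this position also remains open.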